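Nitro in Place of Acetyl: An Antiproliferative Estimate

The compounds below may be only part of what the source reports. "The series", "measured", "known", "first", "only" and "open" are said of these compounds alone.

In a functional assay on HT-29 cells (Homo sapiens) for antiproliferative activity, read by MTT assay, with a stated time of 72 h (on this read-out higher numbers stand for weaker inhibition and lower numbers for stronger inhibition), compound 1 (`Nc1nc(N)c2cc(CSC(=S)N3CCN(c4ccc(F)cc4)CC3)ccc2n1`) gives 2050 nM, compound 2 (`Nc1nc(N)c2cc(CSC(=S)N3CCN(c4ccccc4F)CC3)ccc2n1`) gives 5420 nM, and compound 3 (`CC(=O)c1ccc(N2CCN(C(=S)SCc3ccc4nc(N)nc(N)c4c3)CC2)cc1`) gives 2280 nM. Compound 3 stands with compound 1 at the low end of these numbers, and the two lie within the scatter of each other. Compound 4 (`Nc1nc(N)c2cc(CSC(=S)N3CCN(c4ccc([N+](=O)[O-])cc4)CC3)ccc2n1`) carries nitro in place of acetyl on an aromatic carbon, para to a large group: nitro in place of acetyl on an aromatic carbon. The nearest measured swap, acetyl in place of fluoro, was a 1.1-fold higher number from compound 1 to compound 3 (0.05 log units; within the scatter). The larger steps, a 2.6-fold higher number from compound 1 to compound 2 (0.42 log units; beyond the scatter) and a 2.4-fold lower number from compound 2 to compound 3 (0.38 log units; beyond the scatter), both involve 2-fluorophenyl, which is absent here. No step beyond the scatter is therefore expected in this assay. The estimated step is a 1.0-fold lower number from compound 3 to compound 4 (0.02 log units; within the scatter). Compound 4 is expected at 2200 nM, with an estimated range of 1000 nM to 5000 nM.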

Compound 4, half-maximal inhibitory concentration: 3320 nM
Estimate against measurement, compound 4: 1.5-fold (0.18 log units) below; low and high end bracket the measured number.
By their numbers in this assay, from the lowest: compounds 1, 3, 4 and 2 (each within the scatter of the next, the first and the last beyond it).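

In this assay, nitro on this aromatic carbon, para to a large group, cannot be told apart from acetyl (a 1.5-fold higher number from compound 3 to compound 4 (0.16 log units; within the scatter)) or from fluoro (a 1.6-fold higher number from compound 1 to compound 4 (0.21 log units; within the scatter)), so all three groups fall within the scatter at this place. Unlike 4-fluorophenyl and 4-acetylphenyl, 4-nitrophenyl also lies within the scatter of 2-fluorophenyl (a 1.6-fold lower number from compound 2 to compound 4 (0.21 log units; within the scatter)). Nothing available bears on what lies behind these values.

From the compounds shown here alone, whether an amine or a carboxylic acid on this carbon would give a step beyond the scatter remains open.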